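A few compounds are considered here, and "the series" means these few. Any claim that something is new, unique, unknown or untested is made for them only; others in the source may bear on it.

Measured so far:
Compound 1 `Cn1c(-c2ccccc2)nnc1S(C)(=O)=O`: 55 mg/kg
Compound 2 `Cc1ccc(-c2nnc(S(C)(=O)=O)n2C)cc1`: > 200 mg/kg (a limit)
Compound 3 `COc1ccc(-c2nnc([S+](C)[O-])n2C)cc1`: > 100 mg/kg (a limit)

These results come from a functional assay on the whole organism for antagonist activity, with Mus musculus as the target; on this read-out higher numbers stand for an effect only at larger amounts of compound and lower numbers for an effect already at smaller amounts. Compound 3 stands at > 100 mg/kg, which is a limit of the assay and not a number. Compound 2 also gives only a limit, > 200 mg/kg. Of the three, only compound 1 has a true number, 55 mg/kg.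

Compound 4 `COc1ccc(-c2nnc(S(C)(=O)=O)n2C)cc1` is compound 3 with one structural change: a group of 4 heavy atoms (1 carbon, 2 oxygen, 1 sulfur; no ring) in place of a group of 3 heavy atoms (1 carbon, 1 oxygen, 1 sulfur; no ring), on an aromatic carbon. The change lies on an aromatic carbon of a five-membered aromatic ring with 3 nitrogen, between two ring nitrogen atoms. Among the measured compounds shown here, compound 1 and compound 2 carry the same methylsulfonyl group, but no measured pair shows this exact exchange. For the measured compounds named here, the one measured step, an at least 3.6-fold higher number from compound 1 to compound 2 (0.56 log units; beyond the scatter), is a methyl in place of hydrogen on an aromatic carbon. It is a different change, so it cannot set the size or direction here. It does show that the dose can shift beyond the scatter among compounds carrying methylsulfonyl, so the expectation stays wide.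

The estimated step is a number no higher from compound 3 to compound 4 (the limit leaves the size open), and its direction is uncertain. For compound 4 the expected value is 100 mg/kg, with an estimated range of 30 mg/kg to 300 mg/kg.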

Compound 4, dose for half-maximal effect: > 200 mg/kg
Compound 4: no number, only a limit; the forecaster's own chance of this, stated with the estimate: 45%; middle value at least 2.0-fold (0.30 log units) from the limit.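

In this assay, the step with methoxy in place of hydrogen is an at least 3.6-fold higher number from compound 1 to compound 4 (0.56 log units; beyond the scatter), and the step with methyl in place of hydrogen is an at least 3.6-fold higher number from compound 1 to compound 2 (0.56 log units; beyond the scatter), so both groups shown on this aromatic carbon of the core point the same way. The change from the group of compound 3 to methylsulfonyl gives no readable step, and neither does methoxy in place of methyl, since each of these pairs has a limit of the assay at both ends and no true number: the limit of > 200 mg/kg in this assay, at which 2 of the 4 values shown sit. Compound 3 carries a limit of its own: the limit of > 100 mg/kg in this assay, at which 1 of the 4 values shown sits.

The compounds shown leave open how far compound 4 really lies from compound 3 and from compound 2, and so whether methylsulfonyl on the five-membered ring changes the dose at all. They also leave open what an amine or a carboxylic acid would do on the aromatic carbon that carries methoxy in compound 4, and what a longer chain on the sulfur would do in place of the methyl of methylsulfonyl.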